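The compounds below may be only part of what the source reports. "The series", "measured", "known", "first", "only" and "open" are said of these compounds alone.

In a functional assay on HL-60 cells (Homo sapiens) for antiproliferative activity, with a stated time of 72 h (a lower number here means a stronger inhibitor, a higher number a weaker inhibitor), three compounds on the shared core have been measured. Compound 1 (`OC[C@H]1O[C@@H](n2cnc3c(NCc4cccc(F)c4)ncnc32)[C@H](O)[C@@H]1O`) gives 920 nM and compound 2 (`OC[C@H]1O[C@@H](n2cnc3c(NCc4cccc(Br)c4)ncnc32)[C@H](O)[C@@H]1O`) gives 8000 nM while compound 3 (`OC[C@H]1O[C@@H](n2cnc3c(NCc4ccc(Br)cc4)ncnc32)[C@H](O)[C@@H]1O`) gives 47400 nM as the highest number of the three, with its gaps to both others beyond the scatter.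

Compound 4 (`COc1cccc(CNc2ncnc3c2ncn3[C@@H]2O[C@H](CO)[C@@H](O)[C@H]2O)c1`) is unmeasured. It carries 3-methoxyphenyl in place of 4-bromophenyl on a saturated chain carbon bound to a nitrogen on an aromatic ring.

Among the compounds with values here, no measured step makes this exact swap, and no methoxy compound has a value yet. The nearest guides are a 5.9-fold higher number from compound 2 to compound 3 (0.77 log units; beyond the scatter) for the bromo compounds and a 52-fold higher number from compound 1 to compound 3 (1.71 log units; beyond the scatter) for the change from the fluoro compound. Read in reverse, both point to a lower number for a ring substituted as in compound 4, which matches compound 1 and compound 2 in this respect. The spread between those two, an 8.7-fold higher number from compound 1 to compound 2 (0.94 log units; beyond the scatter) on changing the halogen alone, shows that the substituent itself also matters and leaves the range wide.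

A modest to large step toward a lower number is therefore expected in this assay for this change. The estimated step is a 12-fold lower number from compound 3 to compound 4 (1.07 log units; beyond the scatter) in size. Compound 4 is estimated at 4000 nM with an expected range from 900 nM to 18000 nM in this series.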

Compound 4, half-maximal inhibitory concentration: 4900 nM
Beside the measured number, compound 4's estimate is 1.2-fold (0.09 log units) below it; low and high end bracket the measured number.
By their numbers in this assay, from the lowest: compound 1; then compounds 4 and 2 (each within the scatter of the next); then compound 3.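

Working notes on the series: in this assay, the 3-methoxyphenyl group gives a 9.7-fold lower number from compound 3 to compound 4 (0.99 log units; beyond the scatter), so a third group carried as a 3-substituted phenyl, and the first that is not a halogen, also stands well clear of the 4-bromophenyl compound. Among these 3-substituted rings, methoxy in place of bromo gives a 1.6-fold lower number from compound 2 to compound 4 (0.21 log units; within the scatter), while methoxy in place of fluoro gives a 5.3-fold higher number from compound 1 to compound 4 (0.73 log units; beyond the scatter), which leaves the fluoro group of compound 1 with the lowest number of the four and shows that methoxy does not close the gap to it. Nothing available explains these differences in activity.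

The 4-bromophenyl group is the only 4-substituted ring here, so the shift seen with bromo may or may not carry over to 4-methoxyphenyl or 4-fluorophenyl, and the series still lacks an unsubstituted phenyl reference for judging whether any 3-substituent helps at all. On these data alone, how a hydroxyl, a nitrile, an amine or a carboxylic acid on the ring, or a longer chain in place of the benzyl link, would read in this assay also remains open.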